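Thiophene Replacing Methoxyphenyl: An Expected Loss of Inhibition

The compounds below may be only part of what the source reports. "The series", "measured", "known", "first", "only" and "open" are said of these compounds alone.

Measured so far:
compound 1 `COc1ccc(-c2cn3ccnc3c(-c3ccc4ncn(C5CCCCC5)c4c3)n2)cc1`: 80.9%
compound 2 `Fc1ccccc1-c1cn2ccnc2c(-c2ccc3ncn(C4CCCCC4)c3c2)n1`: 11.4%

In a functional assay on U-251 cells (Homo sapiens) for inhibition, read by sulforhodamine B assay, with a stated time of 48 h, tested at 10 uM (a higher number here means more inhibition at the concentration tested (going by the name of the read-out), a lower number less inhibition), compound 1 gives 80.9%, the highest of the two numbers; its nearest neighbour is compound 2, which gives 11.4% in this assay. Compound 3 `c1csc(-c2cn3ccnc3c(-c3ccc4ncn(C5CCCCC5)c4c3)n2)c1` differs from compound 1 as follows: thiophen-2-yl in place of 4-methoxyphenyl on an aromatic carbon. Among the compounds with values here, the one measured step that bears on this change is a number 69.5 percentage points lower from compound 1 to compound 2 (beyond the scatter), where exchanging the same 4-methoxyphenyl gave a large fall. Compound 3 is therefore expected to show a step of a number 40.9 percentage points lower from compound 1 to compound 3 (beyond the scatter) in this assay. For compound 3 the estimate is 40%, with a range from 10% to 75%.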

Compound 3, a percentage reported as inhibition, at one concentration (the size of the read-out at that concentration, not a potency): 3.92%
The estimate for compound 3 lay 36.1 percentage points above the measured number; measured number outside the range, below it.
By their numbers in this assay, from the lowest: compounds 3 and 2 (each within the scatter of the next); then compound 1.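

In this assay, thiophen-2-yl in place of 4-methoxyphenyl also costs nearly all the inhibition (a number 77 percentage points lower from compound 1 to compound 3 (beyond the scatter)), so a second, quite different replacement at this position fails as well. Set against the 2-fluorophenyl group, thiophen-2-yl shows no real difference (a number 7.5 percentage points lower from compound 2 to compound 3 (within the scatter)). Of the three groups, only 4-methoxyphenyl keeps a high number. Nothing available accounts for this behaviour. As far as these compounds go, whether an unsubstituted phenyl, or a phenyl carrying an amine, would hold the inhibition at this position remains open.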